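The compounds below may be only part of what the source reports. "The series", "measured", "known", "first", "only" and "open" are said of these compounds alone.

Compound 1 `CNC(=O)c1cc(C(=O)N[C@H]2CC[C@H](O)CC2)cc2c1OC[C@@]2(C)c1ccccc1`: in a physicochemical assay for solubility (on this read-out lower numbers stand for lower solubility and higher numbers for higher solubility), compound 1 gives >= 161 ug/mL, a limit of the assay rather than a number.
Compound 2 `CC[C@@]1(c2ccccc2)COc2c(C(=O)NC)cc(C(=O)N[C@H]3[C@@H]4COC[C@@H]43)cc21`: compound 2 gives >= 152 ug/mL, again a limit.
Compound 3 `CNC(=O)c1cc(C(=O)N[C@H]2[C@@H]3COC[C@@H]32)cc2c1OC[C@H]2c1cccc2[nH]ccc12`: compound 3 gives >= 171 ug/mL, also a limit.

Compound 1 therefore stands at the limit of >= 161 ug/mL in this assay, at which 1 of the 3 values shown sits, and nothing more precise is known of it in this assay. The two other measured compounds sit at the limit of >= 152 ug/mL in this assay, at which 1 of the 3 values shown sits, and (the limit of >= 171 ug/mL in this assay, at which 1 of the 3 values shown sits), so all three values shown are limits and none separates the compounds from one another. For the measured compounds named here, no step between measured compounds can be drawn from such data.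

The account follows the change from compound 1 to compound 4 `CNC(=O)c1cc(C(=O)N[C@H]2[C@@H]3C[C@H](O)C[C@@H]32)cc2c1OC[C@@]2(C)c1ccccc1`, which differs by a group of 7 heavy atoms (6 carbon, 1 oxygen; one three-membered non-aromatic ring of carbon only, one five-membered non-aromatic ring of carbon only) in place of a group of 7 heavy atoms (6 carbon, 1 oxygen; one six-membered non-aromatic ring of carbon only), on an amide-type nitrogen. Since every measured compound, whatever its amide substituent, has reached a limit in this assay, the expectation for compound 4 is that the change brings no step beyond the usual scatter, in either direction. Compound 4 is thus expected to give an estimated 165 ug/mL, within a range of 110 ug/mL to 250 ug/mL, most probably reported once more as a limit. The step that the limit leaves unreadable from compound 1 to compound 4 is expected to be essentially flat.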

Compound 4, solubility: >= 151 ug/mL
Compound 4: only a limit was reported; the forecaster's own chance of this, stated with the estimate: 80%; the middle value is on the limit's open side.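

In this assay compound 4 gives >= 151 ug/mL, which is a limit of the assay. Compound 1 is also known only as a limit, so no step can be read between compound 1 and compound 4. The compounds shown leave open whether replacing the 4-hydroxycyclohexyl group on the amide-type nitrogen changes the result in this assay at all.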